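A few compounds are considered here, and "the series" means these few. Any claim that something is new, unique, unknown or untested is made for them only; others in the source may bear on it.

Values measured in a functional assay on MCF7 cells (Homo sapiens) for antiproliferative activity; on this read-out lower numbers stand for stronger inhibition and higher numbers for weaker inhibition:
- compound 1 `CC(C)=CCc1cc(C(=O)Nc2cc3ccc(OCC4CCN(C)C4)c(C)c3oc2=O)ccc1O`: 1550 nM
- compound 2 `CCCNCCCOc1ccc2cc(NC(=O)c3ccc(O)c(CC=C(C)C)c3)c(=O)oc2c1C`: 980 nM
- compound 3 `CCCN(CCC)CCCOc1ccc2cc(NC(=O)c3ccc(O)c(CC=C(C)C)c3)c(=O)oc2c1C`: > 50000 nM (a limit, not a number)

Compound 3 stands at the limit of > 50000 nM in this assay, at which 1 of the 3 values shown sits. Compound 4 `CC(C)=CCc1cc(C(=O)Nc2cc3ccc(OCCCNCC(C)C)c(C)c3oc2=O)ccc1O` differs from it by isobutylamino in place of dipropylamino on a saturated chain carbon, three bonds along the chain from an oxygen on an aromatic ring. The closest measured step is an at least 51-fold higher number from compound 2 to compound 3 (1.70 log units; beyond the scatter), a large one made by putting propyl in place of hydrogen on an amine nitrogen. The step of an at least 32-fold higher number from compound 1 to compound 3 (1.50 log units; beyond the scatter) is also large, while a 1.6-fold lower number from compound 1 to compound 2 (0.20 log units; within the scatter) stays within the scatter. Compound 4 keeps a hydrogen on the amine nitrogen, as compound 2 does at 980 nM, so a large step to a lower number is expected in this assay. The expected step is an at least 33-fold lower number from compound 3 to compound 4 (1.52 log units; beyond the scatter). For compound 4 the estimate is 1500 nM, within an expected range of 500 nM to 6000 nM.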

Compound 4, half-maximal inhibitory concentration: 1320 nM
Estimate against measurement, compound 4: 1.1-fold (0.06 log units) above, within the range that was stated.
By their numbers in this assay, from the lowest: compounds 2, 4 and 1 (each within the scatter of the next). At a limit, above all of these: compound 3.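

In this assay, isobutylamino in place of dipropylamino on this chain carbon gives an at least 37-fold lower number from compound 3 to compound 4 (1.57 log units; beyond the scatter), so a second group with a hydrogen on the amine nitrogen also stands far from compound 3. Compound 3 is held only by a limit: the limit of > 50000 nM in this assay, at which 1 of the 4 values shown sits. Added methyl gives a 1.3-fold higher number from compound 2 to compound 4 (0.13 log units; within the scatter), and the change from the ring gives a 1.2-fold lower number from compound 1 to compound 4 (0.07 log units; within the scatter), so these side chains cannot be told apart here.

Compound 1 has no hydrogen on its amine nitrogen, which goes against a rule based on that hydrogen. Going by these compounds, whether dimethylamino would fall with compound 3 or compound 4 stays open.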